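The compounds below may be only part of what the source reports. "The series", "measured", "known", "first", "only" and "open" are said of these compounds alone.

Compound 1 `O=C(c1sc(-c2cccc(F)c2)nc1O)N1CCCOC1`: in an assay on HEK293 cells for inhibition of transient receptor potential cation channel subfamily M member 8 (Homo sapiens), read by FLIPR, with stated times of 5 min and 3 min (a higher number here means a weaker inhibitor, a lower number a stronger inhibitor), compound 1 gives > 100000 nM, a limit of the assay.
Compound 2 `CCOC(=O)c1sc(-c2ccccc2)nc1CO`: in this assay compound 2 gives > 100000 nM, again a limit.
Compound 3 `CCn1nnnc1-c1sc(-c2cccc(F)c2)nc1O`: in this assay compound 3 gives > 100000 nM, also a limit.

Compound 2 therefore stands nowhere apart from the other two: it shares (the limit of > 100000 nM in this assay, at which 3 of the 3 values shown sit), and no ordering among the three can be read from these figures. Compound 4 `CCOC(=O)c1sc(-c2ccccc2)nc1OC` differs from compound 2 in one place, (methoxy in place of hydroxymethyl on an aromatic carbon). For the measured compounds named here, no measured pair shows what such a change does, and every number so far is a limit rather than a value. The step of a number no higher from compound 2 to compound 4 (the limit leaves the size open) is expected to be none beyond the usual scatter. Compound 4 is accordingly estimated at 100000 nM in this assay, within 20000 nM to 300000 nM.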

Compound 4, half-maximal inhibitory concentration: > 100000 nM
Compound 4 ended at the assay's limit; the forecaster's own chance of this, stated with the estimate: 80%; the middle value sits exactly at the limit.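

No step can be read from compound 2 to compound 4, since in this assay both stand at a limit: the limit of > 100000 nM in this assay, at which 4 of the 4 values shown sit.

The compounds shown leave open whether methoxy in place of hydroxymethyl changes inhibition at all, and which of the four inhibits more strongly.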